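The source may hold more compounds than are shown below. What is called first, only, known or untested is meant among the compounds shown, and "the series" means these compounds.

Measured compounds:
- compound 1, `CN1CCN(CCCOc2cccc3nc(Nc4ccc(Cl)c(C(F)(F)F)c4)ccc23)CC1`: in a functional assay on cells (Panel NCI-60 (60 carcinoma cell lines), Homo sapiens) for inhibition, read by sulforhodamine B assay, with a stated time of 48 h (a lower number here means a stronger inhibitor of growth, a higher number a weaker inhibitor of growth), compound 1 gives 3470 nM
- compound 2, `CN1CCN(CCCOc2cccc3nc(Nc4ccc(Cl)c(F)c4)ccc23)CC1`: in this assay compound 2 gives 3890 nM

Within the data shown here, compound 2 has the higher of the two numbers, but its only neighbour is compound 1, and the difference between them is small: a 1.1-fold higher number from compound 1 to compound 2 (0.05 log units; within the scatter). Among the measured compounds shown here, that single step, fluoro in place of trifluoromethyl on an aromatic carbon, is also the only change so far that swaps one halogen-bearing group for another on the same ring.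

Compound 3, `CN1CCN(CCCOc2cccc3nc(Nc4ccc(F)c(F)c4)ccc23)CC1`, has not yet been tested in this assay. It differs from compound 2 by fluoro in place of chloro on an aromatic carbon. For the measured compounds named here, the one step that bears on this change is the one from compound 1 to compound 2, and it stayed within the scatter. With nothing else to go on, the expectation is that this further halogen swap will likewise produce no step beyond the scatter, and the estimated step is a 1.0-fold higher number from compound 2 to compound 3 (0.01 log units; within the scatter). Compound 3 is therefore expected to give 4000 nM, within a range from 1800 nM to 9000 nM.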

Compound 3, concentration for total growth inhibition: 6760 nM
Compound 3: the middle estimate sits 1.7-fold (0.23 log units) below what was measured; measured number inside the range.
By their numbers in this assay, from the lowest: compounds 1, 2 and 3 (each within the scatter of the next).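

In this assay, taking the chloro away from the ring and putting a fluoro in its place, so that 4-chloro-3-fluorophenyl becomes 3,4-difluorophenyl, gives a small step (a 1.7-fold higher number from compound 2 to compound 3 (0.24 log units; within the scatter)). Among these compounds, this is the first look at the place para to a large group, and there, too, a change of halogen stays within the scatter. Exchanging the whole ring substituent pattern, with 3,4-difluorophenyl in place of 4-chloro-3-(trifluoromethyl)phenyl, also gives no step beyond the scatter (a 1.9-fold higher number from compound 1 to compound 3 (0.29 log units; within the scatter)), so this ring has so far tolerated changes in both of its substituted places, and nothing measured here offers an explanation for that.

The compounds shown carry only chloro, fluoro and trifluoromethyl on this ring, so what a methoxy group, an amine or a carboxylic acid would do in the same place remains open. The shared core and its side chain are identical in all three compounds, so whether a longer chain there would give a step beyond the scatter is open as well.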